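A few compounds are considered here, and "the series" means these few. Any claim that something is new, unique, unknown or untested is made for them only; others in the source may bear on it.

Compound 1, `COc1ccc(C2=C(c3cc(OC)c(OC)c(OC)c3)C(=O)C(O[SiH2]C(C)(C)C)C2)cc1OC(C)C`: 7.1 ug/mL
Compound 2, `COCOc1cc(C2=C(c3cc(OC)c(OC)c(OC)c3)C(=O)CC2O[SiH2]C(C)(C)C)ccc1OC`: 13.5 ug/mL

Both compounds were tested in an ADME assay on PA-1 cells (Homo sapiens) for cytotoxicity, read by MTT assay, with a stated time of 72 h (a higher number here means a weaker inhibitor, a lower number a stronger inhibitor), which reports how much of each substance is needed to reach the stated level of inhibition of cell growth. Compound 2 gives 13.5 ug/mL in this assay, and compound 1 gives 7.1 ug/mL. The gap between these two numbers lies within the usual scatter of such measurements, so the two compounds cannot be told apart on this evidence; neither can be called the stronger or the weaker.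

Compound 3, `COc1ccc(C2=C(c3cc(OC)c(OC)c(OC)c3)C(=O)CC2O[SiH2]C(C)(C)C)cc1O`, has not yet been measured. It differs from compound 2 at a single position:

hydrogen in place of methoxymethyl on an oxygen on an aromatic ring

Within the data shown here, no pair of measured compounds shows the effect of this particular change, so there is no measured step to lean on. The expectation for compound 3 therefore rests only on the value of compound 2, 13.5 ug/mL, and on the small size of the change. A step of modest size toward a lower number is expected, a 2.3-fold lower number from compound 2 to compound 3 (0.35 log units; beyond the scatter), though it may well fall within the scatter. Compound 3 is estimated at 6 ug/mL in this assay, with a likely range from 1.5 ug/mL to 20 ug/mL.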

Compound 3, half-maximal inhibitory concentration: 14 ug/mL
Compound 3: middle estimate off by 2.3-fold (0.37 log units), on the low side; the measured number falls inside the stated range.
By their numbers in this assay, from the lowest: compounds 1, 2 and 3 (each within the scatter of the next).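

In this assay, among these compounds, exchanging methoxymethyl for hydrogen on an oxygen on an aromatic ring gives a 1.0-fold higher number from compound 2 to compound 3 (0.02 log units; within the scatter), the first measured step at this position. The two compounds cannot be told apart here: the methoxymethoxy group and the hydroxy group, which differ by 3 heavy atoms, give readings within the usual scatter of the measurement, so this pair shows no detectable effect of the exchange in this assay. No measurement offered here accounts for that outcome.

The finding rests on a single pair sharing one core, so it cannot be said whether a much longer chain on this oxygen, such as an octyl chain, or one ending in an amine or a carboxylic acid, would also stay within the scatter. On these data alone, it also remains open whether the same exchange would give a similar step if made on a different core, or in a test on a different kind of cell.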